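This account rests on a few compounds, and the source may have more. Where it says the series, first, only, none or still open, it means among the compounds named here.

Measured so far:
compound 1 `C[Se]c1nc([Se]C)c2cccnc2n1` — "not determined" (no result reported)
compound 2 `CCCCC[Se]c1nc([Se]CCCCC)c2ccccc2n1` — 65700 nM

Compound 1, `C[Se]c1nc([Se]C)c2cccnc2n1`, carries no value in a functional assay on CCRF-CEM cells (Homo sapiens) for cytotoxicity, read by MTT assay, with a stated time of 72 h; on this read-out higher numbers stand for weaker inhibition of growth and lower numbers for stronger inhibition of growth. Within the data shown here, compound 2, `CCCCC[Se]c1nc([Se]CCCCC)c2ccccc2n1`, in this assay gives 65700 nM; this is the only number, and since compound 1 lacks a result there is no step between measured compounds to lean on. Compound 2 therefore stands alone, at a level of weak growth inhibition.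

Compound 3, `CCCCC[Se]c1nc(NCc2ccccc2)c2ccccc2n1`, is still to be measured in this assay. Against compound 2 the change is a group of 8 heavy atoms (7 carbon, 1 nitrogen; one six-membered aromatic ring of carbon only) in place of a group of 6 heavy atoms (5 carbon, 1 selenium; no ring), on an aromatic carbon: in words, a group of 8 heavy atoms (7 carbon, 1 nitrogen; one six-membered aromatic ring of carbon only) in place of a group of 6 heavy atoms (5 carbon, 1 selenium; no ring), on an aromatic carbon. The core of compound 2 is otherwise kept.

Without a measured step in the series, the expectation rests on the structural change alone. The step of a 3.3-fold lower number from compound 2 to compound 3 (0.52 log units; beyond the scatter) is expected to point toward stronger inhibition, modestly beyond the scatter, but with wide uncertainty. For compound 3 the estimated value in this assay is 20000 nM, with a range from 4000 nM to 100000 nM. A reported limit rather than a number for compound 3 cannot be ruled out.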

Compound 3, concentration for 50% growth inhibition: 34500 nM
Compound 3: middle estimate off by 1.7-fold (0.24 log units), on the low side; the range from low to high includes it.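

In this assay, benzylamino in place of the group of 6 heavy atoms (5 carbon, 1 selenium; no ring), on the aromatic carbon next to the ring nitrogen, gives a 1.9-fold lower number from compound 2 to compound 3 (0.28 log units; within the scatter). This first readable step shows that this position tolerates the exchange without a shift beyond the scatter, even though a six-membered aromatic ring, a hydrogen-bond donor and a hydrogen-bond acceptor enter with the new group, so the selenium group at this position is not required for growth inhibition at this level. No measurement here offers an explanation for why compound 2 and compound 3 read alike.

A single exchange cannot show whether this position is generally insensitive or whether benzylamino simply happens to match the group it replaces; a small amine such as plain amino, a cyclic amine such as morpholine, or a carboxylic acid at the same carbon would test that. The selenium group kept in both compounds also remains unprobed as a single change, and a longer chain or a shorter ethyl chain there would show whether the shared part governs the level of growth inhibition.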